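The compounds below may be only part of what the source reports. "The series", "measured", "known", "first", "only" and "open" are said of these compounds alone.

Working notes on the series, read in an ADME assay on MT4 cells (Homo sapiens) for cytotoxicity, read by MTT assay, with a stated time of 96 h; a higher number here means that more compound is tolerated, a lower number that less compound is tolerated. Compound 2 (`COc1ccc(-c2nc3cc(C(C)O)ccc3[nH]2)c(OC)c1`) gives >= 100000 nM, which is a limit of the assay and not a number. Compound 1 (`COc1ccc(-c2nc3cc(C(C)O)ccc3[nH]2)cc1`) gives >= 100000 nM, likewise a limit. Compound 3 (`C/C(=N\O)c1ccc2[nH]c(-c3ccccc3)nc2c1`) carries the entry "not determined" (no result reported) and adds nothing to the comparison. Within the data shown here, compound 2 therefore stands at the limit of >= 100000 nM in this assay, at which 2 of the 3 values shown sit, and the series so far holds no single number.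

The next compound is compound 4 (`COc1ccc(-c2nc3cc(/C(C)=N/NC(N)=S)ccc3[nH]2)c(OC)c1`). It differs from compound 2 as follows: a group of 7 heavy atoms (3 carbon, 3 nitrogen, 1 sulfur; no ring) in place of a group of 3 heavy atoms (2 carbon, 1 oxygen; no ring), on an aromatic carbon. The 1-hydroxyethyl leaves, and the new group takes its place on the same aromatic carbon.

Among the measured compounds shown here, the only measured step is a step that the two limits leave unreadable from compound 1 to compound 2, with methoxy in place of hydrogen on an aromatic carbon. For the measured compounds named here, it has no readable size and concerns a different kind of change, so no measured step bears directly on this replacement. The expectation rests on the structural change alone, and it is tentative. A move towards less compound being tolerated is expected, with the estimated size being an at least 4.0-fold lower number from compound 2 to compound 4 (0.60 log units; beyond the scatter). A further limit reading remains possible. For compound 4 the expected value is 25000 nM, with an estimated range from 4000 nM to 100000 nM.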

Compound 4, half-maximal cytotoxic concentration: 72000 nM
Compound 4: the middle estimate sits 2.9-fold (0.46 log units) below what was measured, within the range that was stated.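

Compound 4 gives the series its first single number in this assay, which shows that a replacement on this aromatic carbon can bring the reading inside the measurable range, something neither compound 1 nor compound 2 could show. Putting the group of 7 heavy atoms (3 carbon, 3 nitrogen, 1 sulfur) in place of the 1-hydroxyethyl gives an at least 1.3-fold lower number from compound 2 to compound 4 (0.14 log units; that floor lies within the scatter), so the floor alone does not establish a real change for this replacement. The step stays a floor and not a size, since the reading for compound 2 is a limit of the assay and not a number: the limit of >= 100000 nM in this assay, at which 2 of the 4 values shown sit.

The compounds shown leave open which part of the new group accounts for the reading, and whether an amine or a carboxylic acid on the same aromatic carbon would read as a single number or stay at the limit. They also leave open how the same replacement reads on the core of compound 1, which carries one methoxy fewer than compound 4.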